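A few compounds are considered here, and "the series" means these few. Any claim that something is new, unique, unknown or untested is made for them only; others in the source may bear on it.

Compound 3 `C=CC[C@@]12CCN(C(=O)OC(C)(C)C)[C@@H]1n1c3nc4ccc(O)cc4cc3c(=O)c3cccc2c31` gives 32700 nM in a functional assay on NCI-H460 cells (Homo sapiens) for inhibition, read by trypan blue exclusion, with a stated time of 72 h (a higher number here means a weaker inhibitor of growth, a lower number a stronger inhibitor of growth), the lowest of the three numbers in hand, though its steps to both neighbours stay within the scatter. Compound 1 `C=CC[C@@]12CCN(C)[C@@H]1n1c3nc4ccc(OC)cc4cc3c(=O)c3cc(OC)cc2c31` gives 50000 nM in this assay, and compound 2 `C=CC[C@@]12CCN[C@@H]1n1c3nc4ccc(O)cc4cc3c(=O)c3cccc2c31` gives 50000 nM. Among the measured compounds shown here, the only measured step, a 1.5-fold lower number from compound 2 to compound 3 (0.18 log units; within the scatter), concerns the amine nitrogen and does not touch the chain. Compound 4 `CC(C)(C)OC(=O)N1CC[C@@]2(CCO)c3cccc4c(=O)c5cc6cc(O)ccc6nc5n(c34)[C@@H]12` differs from compound 3 by hydroxymethyl in place of vinyl on a saturated chain carbon bound to a saturated ring carbon. For the measured compounds named here, no measured pair bears on this exchange, so nothing argues for a step beyond the scatter in either direction, and compound 4 is expected to sit close to compound 3, with a 1.2-fold higher number from compound 3 to compound 4 (0.09 log units; within the scatter) as the estimated step. Compound 4 is therefore estimated at 40000 nM in this assay, within the range 15000 nM to 100000 nM.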

Compound 4, concentration for 50% growth inhibition: 26800 nM
For compound 4 the middle estimate is 1.5-fold (0.17 log units) above the measured one; the range from low to high includes it.
By their numbers in this assay, from the lowest: compounds 4, 3, 1 and 2 (each within the scatter of the next).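

In this assay, among the compounds shown here, the exchange of allyl for 2-hydroxyethyl gives a 1.2-fold lower number from compound 3 to compound 4 (0.09 log units; within the scatter), the first measured step at this position, so this chain can carry hydroxymethyl in place of vinyl without a step beyond the scatter. No evidence at hand bears on why the two numbers stay so close.

The compounds shown leave open whether an amine or a carboxylic acid on this chain, or a longer chain, would stand apart from compound 3. They also leave open whether the same exchange would read alike with hydrogen in place of tert-butoxycarbonyl on the ring nitrogen.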